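Second furan-2-yl on compound 2

The compounds below may be only part of what the source reports. "The series", "measured", "known", "first", "only" and "open" are said of these compounds alone.

Measured so far in a functional assay on HeLa cells (Homo sapiens) for cytotoxicity (on this read-out lower numbers stand for stronger inhibition and higher numbers for weaker inhibition), as follows
- compound 1 `Nc1[nH]nc2nnc(-c3ccc(-c4ccccc4)cc3)c(-c3ccc(-c4ccccc4)cc3)c12` gives > 100000 nM as a limit
- compound 2 `Nc1[nH]nc2nnc(-c3ccco3)cc12` gives > 100000 nM as a limit

For compound 2 the entry of > 100000 nM is a limit of the assay and not a number. Within the data shown here, the series so far offers only the limit of > 100000 nM in this assay, at which 2 of the 2 values shown sit, and no measured step between compounds. Compound 3 `Nc1[nH]nc2nnc(-c3ccco3)c(-c3ccco3)c12` follows from compound 2 by the change furan-2-yl in place of hydrogen on an aromatic carbon with furan-2-yl in place of hydrogen on an aromatic carbon. Compound 1 also carries two aryl groups on the core and gives > 100000 nM as a limit. On that basis no step beyond the scatter is expected in this assay and no clear direction is expected either. The expected change is a number no higher from compound 2 to compound 3 (the limit leaves the size open) in this estimate. Compound 3 is estimated at 100000 nM with a range of 30000 nM to 200000 nM. A limit of the assay is expected for compound 3 as well.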

Compound 3, half-maximal inhibitory concentration: > 100000 nM
Compound 3 ended at the assay's limit (the forecaster's own chance of this, stated with the estimate: 75%); the middle value lies on the limit itself.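

The step from compound 2 to compound 3 cannot be read: both entries in this assay are limits of the assay and not numbers. The compounds shown leave open whether furan-2-yl in place of hydrogen on the shared core changes the read-out at all, and in which direction.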